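Half-Life of Compound 4: One Ring Turns Aromatic

The source may hold more compounds than are shown below. What is called first, only, known or untested is meant among the compounds shown, and "the series" means these compounds.

In an ADME assay (liver) for metabolic stability, with Liver microsome (Homo sapiens) as the target, using microsomes (on this read-out higher numbers stand for a longer-lived compound and lower numbers for a shorter-lived compound), compound 1 `CCc1nc2cc(Cl)ccn2c1C(=O)NCc1ccc(-c2ccncc2)cc1` gives 0.482 h, and compound 2 `CCc1nc2cc(Cl)ccn2c1C(=O)NCc1ccc(N2CCC(Cl)CC2)cc1` gives 0.183 h. Compound 3 `CCc1nc2cc(Cl)ccn2c1C(=O)NCc1ccc(N2CC3CCCCC3C2)cc1`, at 0.248 h, lies inside that span and within the usual scatter of both.

Compound 4 `CCc1nc2cc(Cl)ccn2c1C(=O)NCc1ccc(-n2cc3c(c2)CCCC3)cc1` changes one group of compound 3: a group of 9 heavy atoms (8 carbon, 1 nitrogen; one five-membered aromatic ring with 1 hetero atom, one six-membered non-aromatic ring of carbon only) in place of a group of 9 heavy atoms (8 carbon, 1 nitrogen; one five-membered non-aromatic ring with 1 hetero atom, one six-membered non-aromatic ring of carbon only), on an aromatic carbon. Among the compounds with values here, no measured pair tests this exact change. The closest evidence is small: a 1.9-fold lower number from compound 1 to compound 3 (0.29 log units; within the scatter), and a 1.4-fold higher number from compound 2 to compound 3 (0.13 log units; within the scatter). Within the data shown here, only one step, a 2.6-fold lower number from compound 1 to compound 2 (0.42 log units; beyond the scatter), exceeds the scatter, and it is modest. No clear shift in either direction is therefore expected. The estimated step is a 1.1-fold higher number from compound 3 to compound 4 (0.05 log units; within the scatter). Compound 4 is expected at 0.28 h, with an estimated range of 0.11 h to 0.65 h.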

Compound 4, half-life: 0.455 h
Compound 4: middle estimate off by 1.6-fold (0.21 log units), on the low side, within the range that was stated.
By their numbers in this assay, from the lowest: compounds 2, 3, 4 and 1 (each within the scatter of the next, the first and the last beyond it).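

Turning the five-membered ring aromatic, at the place para to a large group, gives a 1.8-fold higher number from compound 3 to compound 4 (0.26 log units; within the scatter) in this assay, so this change alone shows no clear effect. Against the 4-chloropiperidin-1-yl group, compound 4 shows a 2.5-fold higher number from compound 2 to compound 4 (0.40 log units; beyond the scatter) and so joins the pyridin-4-yl compound at the upper end, with a 1.1-fold lower number from compound 1 to compound 4 (0.03 log units; within the scatter) between those two. No measurement shown here explains these numbers.

Still open, going by these compounds, is whether an amine or a carboxylic acid on the six-membered non-aromatic ring would shift the number in this assay beyond the scatter.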